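A few compounds are considered here, and "the series" means these few. Any claim that something is new, unique, unknown or untested is made for them only; others in the source may bear on it.

Three measured compounds share one core and differ only in the chain attached to the double-bonded nitrogen. In a functional assay on the whole organism (blood, strain Wistar-Okamoto) with Rattus norvegicus as the target, with a stated time of 5 days (on this read-out higher numbers stand for an effect only at larger amounts of compound and lower numbers for an effect already at smaller amounts), compound 1 `CCC/N=C(\NC#N)Nc1cccnc1` gives 20 mg/kg, compound 2 `CCCCC/N=C(\NC#N)Nc1cccnc1` gives 20 mg/kg and compound 3 `CC(C)C/N=C(\NC#N)Nc1cccnc1` gives 20 mg/kg. Compound 3 thus stands level with both of the others. The steps of no change at the digits printed from compound 1 to compound 2 (within the scatter), no change at the digits printed from compound 1 to compound 3 (within the scatter) and no change at the digits printed from compound 2 to compound 3 (within the scatter) all stayed within the scatter, so within these three compounds the chain has not moved the read-out. Compound 4 `CCC(C)/N=C(\NC#N)Nc1cccnc1` carries the change (sec-butyl in place of isobutyl on a double-bonded nitrogen). The nearest guide is the step of no change at the digits printed from compound 2 to compound 3 (within the scatter), also a reshaping of that same chain, which showed nothing. Compound 4 is therefore expected to show no change at the digits printed from compound 3 to compound 4 (within the scatter). The estimate for compound 4 is 20 mg/kg, expected to fall between 10 mg/kg and 40 mg/kg.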

Compound 4, minimum effective dose: 20 mg/kg
Compound 4: middle estimate and measured number agree at the digits printed, and the stated range covers the measured number.
By their numbers in this assay, from the lowest: compounds 1, 2, 3 and 4 (each within the scatter of the next).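

In this assay the sec-butyl chain places a branch on the saturated chain carbon bound to the double-bonded nitrogen, which none of the earlier chains had, yet there is no change at the digits printed from compound 3 to compound 4 (within the scatter) and no change at the digits printed from compound 2 to compound 4 (within the scatter) and also no change at the digits printed from compound 1 to compound 4 (within the scatter). Branching at that carbon is thus tolerated here, just as branching further along the chain was. Nothing available explains why the read-out stays flat.

Still open, as far as these compounds go, is whether a cyclohexyl ring, an amine-bearing chain or a chain longer than pentyl on this nitrogen would shift the minimum effective dose. Any such shift would show where this tolerance ends.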